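The compounds below may be only part of what the source reports. "The series", "measured", "known", "first", "only" and "open" are said of these compounds alone.

Measured compounds:
- Compound 1, `COc1ccc(S(=O)(=O)Nc2ccccc2NS(=O)(=O)c2ccc(OC)cc2)cc1`, gives 16700 nM
- Compound 2, `CC(=O)Nc1ccc(S(=O)(=O)Nc2ccccc2NS(=O)(=O)c2ccc(NC(C)=O)cc2)cc1`, gives 62500 nM
- Compound 3, `Cc1ccc(S(=O)(=O)Nc2ccccc2NS(=O)(=O)c2ccc(C)c(Cl)c2)cc1Cl`, gives 2300 nM

These three share a central ring carrying two sulfonamide arms, and they were all tested in an assay for binding affinity to protein lin-28 homolog A (Mus musculus), with a stated time of 1 h; on this read-out higher numbers stand for weaker inhibition and lower numbers for stronger inhibition. On this read-out compound 3 stands lowest of the three numbers: compound 1 sits higher, by a gap beyond the usual scatter, and compound 2 sits higher still, also beyond the scatter. So compound 3 is the strongest binder of the three measured.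

Compound 4, `Cc1ccc(S(=O)(=O)Nc2ccc(F)cc2NS(=O)(=O)c2ccc(C)c(Cl)c2)cc1Cl`, keeps everything of compound 3 and differs in one place only: fluoro in place of hydrogen on an aromatic carbon. Among the compounds with values here, no pair of measured compounds differs in a single place, so there is no directly comparable step to lean on. A single fluorine swapped for a hydrogen on the central ring is a small change, and the expectation is a step in this assay that stays within the usual scatter, neither clearly up nor down, a 1.2-fold lower number from compound 3 to compound 4 (0.06 log units; within the scatter). Compound 4 is therefore estimated at 2000 nM, with a range from 700 nM to 6000 nM.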

Compound 4, half-maximal inhibitory concentration: 3700 nM
Compound 4: middle estimate off by 1.9-fold (0.27 log units), on the low side; the measured number falls inside the stated range.
By their numbers in this assay, from the lowest: compounds 3 and 4 (each within the scatter of the next); then compound 1; then compound 2.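

Measured in this assay the swap of fluoro in place of hydrogen gives a step that stays within the usual scatter (a 1.6-fold higher number from compound 3 to compound 4 (0.21 log units; within the scatter)), so compound 3 and compound 4 cannot be told apart on this read-out. This is the first change in a single place among the compounds shown, and it indicates that this aromatic carbon, meta to a large group and para to a large group, can carry a fluoro without a clear gain or loss in binding. Nothing measured here speaks to the reason for this result.

As far as these compounds go, one fluoro on one carbon says little about larger groups, so whether this carbon would accept a methoxy group, an amine or a carboxylic acid remains open. From the compounds shown here alone, how the same fluoro would behave on the other carbons of that ring also remains open.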